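The compounds below may be only part of what the source reports. "The series", "measured", "known", "first", "only" and "open" are said of these compounds alone.

Notes on the series. Compound 1 `CCC1Nc2cccc([C@@H]3C[C@H]3CNC(=O)C(C)C)c2O1` gives 0.2 nM in an assay on NIH3T3 cells with melatonin receptor type 1A (Homo sapiens) as the target; a higher number here means a weaker inhibitor, a lower number a stronger inhibitor. For the measured compounds named here, compound 2 `CCCC1Nc2cccc([C@@H]3C[C@H]3CNC(=O)C(C)C)c2O1` gives 4.9 nM in this assay, and the single-point step a 25-fold higher number from compound 1 to compound 2 (1.39 log units; beyond the scatter) is the only measured step so far. Compound 3 `CCC(=O)NC[C@@H]1C[C@H]1c1cccc2c1OC(C(C)C)N2` gives 4.9 nM in this assay, level with compound 2 at the digits shown and, together with it, the highest number of the three; its nearest neighbour is compound 2, its furthest compound 1.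

Compound 4 `CC(C)C(=O)NC[C@@H]1C[C@H]1c1cccc2c1OC(C(C)C)N2` differs from compound 3 by methyl in place of hydrogen on a saturated chain carbon bound to a carbonyl carbon and a saturated chain carbon. Going by the values given here, the one measured step, a 25-fold higher number from compound 1 to compound 2 (1.39 log units; beyond the scatter), concerns the chain on the saturated ring carbon of the shared core and does not bear on a change at the amide chain; nothing measured does. The expected step is therefore a 1.4-fold lower number from compound 3 to compound 4 (0.15 log units; within the scatter) in this assay, not beyond the scatter. For compound 4 the estimate in this assay is 3.5 nM, range 1 nM to 12 nM.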

Compound 4, inhibition constant: 1.3 nM
Beside the measured number, compound 4's estimate is 2.7-fold (0.43 log units) above it; measured number inside the range.
By their numbers in this assay, from the lowest: compound 1; then compound 4; then compounds 2 and 3 (each within the scatter of the next).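

At the amide chain, methyl in place of hydrogen gives a 3.8-fold lower number from compound 3 to compound 4 (0.58 log units; beyond the scatter), the first sign in this assay that this position responds to the change. With isopropylcarbonyl held constant, isopropyl on the saturated ring carbon falls on neither side of a simple chain-length order, giving a 3.8-fold lower number from compound 2 to compound 4 (0.58 log units; beyond the scatter) and a 6.5-fold higher number from compound 1 to compound 4 (0.81 log units; beyond the scatter). The same added methyl therefore does not carry one direction across the series: the same change on two cores in this assay, a 25-fold higher number (1.39 log units; beyond the scatter) from compound 1 to compound 2 and a 3.8-fold lower number (0.58 log units; beyond the scatter) from compound 3 to compound 4, 92-fold (1.97 log units) apart, beyond the scatter of two such steps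

As far as these compounds go, whether the amide-chain change holds with the ethyl group of compound 1 on the saturated ring carbon remains open. So does the effect of a longer chain, such as butanoyl, at the amide.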